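A few compounds are considered here, and "the series" means these few. Any claim that something is new, unique, unknown or untested is made for them only; others in the source may bear on it.

Working notes on the series. The shared core carries a 5-arylidene thiazolidinedione joined through an aryloxyacetamide to a varying nitrogen substituent. Going by the values given here, in a functional assay on PC-3 cells (Homo sapiens) for cytotoxicity, read by sulforhodamine B assay, with a stated time of 48 h (on this read-out lower numbers stand for stronger inhibition of growth and higher numbers for weaker inhibition of growth), compound 3 `O=C(COc1ccc(/C=C2\SC(=O)NC2=O)cc1)Nc1nc2ccccc2s1` gives 28200 nM, which is the only full number among the three measured compounds. Compound 1 `Cc1c(NC(=O)COc2ccc(/C=C3\SC(=O)NC3=O)cc2)c(=O)n(-c2ccccc2)n1C` returns only a limit in this assay, < 100000 nM. Compound 2 `CCCCC1=NC2(CCCC2)C(=O)N1C(=O)COc1ccc(/C=C2/SC(=O)NC2=O)cc1` likewise returns only a limit, < 100000 nM. Compound 3 therefore stands alone as the one quantified point, and the other two, because of the limit of < 100000 nM in this assay, at which 2 of the 3 values shown sit, allow no ranking against it.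

Among the compounds with values here, no pair of measured compounds differs in a single place, so no measured step is available. Compound 4 `Cc1cc(NC(=O)COc2ccc(/C=C3\SC(=O)NC3=O)cc2)no1` is obtained from compound 3 by the change 5-methyl-1,2-oxazol-3-yl in place of 1,3-benzothiazol-2-yl on an amide-type nitrogen. Within the data shown here, with no measured step to anchor it, the expectation is a modest move toward weaker growth inhibition, of a size that may not clear the usual scatter, expressed as a 1.4-fold higher number from compound 3 to compound 4 (0.15 log units; within the scatter). Compound 4 is thus estimated at 40000 nM in this assay, with a range from 14000 nM to 100000 nM.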

Compound 4, concentration for 50% growth inhibition: < 100000 nM
Compound 4: a limit, no number; the forecaster's own chance of this, stated with the estimate: 30%; the middle value lies beyond the limit too.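

In this assay compound 4 gives < 100000 nM as a limit and not a number. No step from compound 3 to compound 4 can be read, because of this limit: the limit of < 100000 nM in this assay, at which 3 of the 4 values shown sit.

The compounds shown leave open whether 5-methyl-1,2-oxazol-3-yl in place of 1,3-benzothiazol-2-yl on an amide-type nitrogen changes growth inhibition, and in which direction.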